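The source may hold more compounds than are shown below. What is called first, only, known or untested is meant among the compounds shown, and "the series" means these compounds.

Compound 2 `CCCS(=O)(=O)Nc1cccc2c1CCC2c1ncc[nH]1` is the lower of the two measured compounds in a functional assay on CHO cells for agonist activity at Alpha-1A adrenergic receptor (Homo sapiens), read by FLIPR and calcium flux (a lower number here means a smaller maximal response, a higher number a larger maximal response), where compound 2 gives 54%; compound 1 `Cc1n[nH]cc1-c1cccc2c1CCC2c1ncc[nH]1` gives 91%. Compound 3 `c1cc(-c2ccn[nH]2)c2c(c1)C(c1ncc[nH]1)CC2` differs from compound 2 in one place: 1H-pyrazol-5-yl in place of (propylsulfonyl)amino on an aromatic carbon. Going by the values given here, the single measured step bearing on this is a number 37 percentage points lower from compound 1 to compound 2 (beyond the scatter), the loss of a pyrazole ring. Reversing that loss with a closely related pyrazole is expected to raise the response by a comparably large amount, so compound 3 is expected to reach 82% (range 62% to 100%), a step of a number 28 percentage points higher from compound 2 to compound 3 (beyond the scatter).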

Compound 3, largest response reached (Emax), in percent of the reference or control that the assay uses: 83%
The estimate for compound 3 lay 1 percentage points below the measured number, within the range that was stated.
By their numbers in this assay, from the lowest: compound 2; then compounds 3 and 1 (each within the scatter of the next).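

In this assay, putting a pyrazole back on this aromatic carbon gives a number 29 percentage points higher from compound 2 to compound 3 (beyond the scatter), so a high response is seen again on the same core with a second pyrazole, not only with the first. Replacing 3-methyl-1H-pyrazol-4-yl with 1H-pyrazol-5-yl gives a number 8 percentage points lower from compound 1 to compound 3 (within the scatter), so these two pyrazoles cannot be told apart here, even with the methyl gone and the ring attached differently.

Nothing available explains why the response changes with these groups. On these data alone, whether a phenyl ring, an amine or a carboxylic acid at this carbon would give a high or a low response remains open.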